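The compounds below may be only part of what the source reports. "The series", "measured", "known", "first", "only" and "open" are said of these compounds alone.

Compound 2 `CC#C[C@@H](CC(=O)O)c1ccc(OC[C@H]2COc3ccc(Cl)cc3O2)cc1` gives 50 nM in a functional assay on HEK293 cells for agonist activity at Free fatty acid receptor 1 (Homo sapiens), read by fluorescence and calcium flux, with a stated time of 10 min (on this read-out lower numbers stand for an effect already at smaller amounts and higher numbers for an effect only at larger amounts of compound), and stands lowest of the three numbers, with compound 1 inside the usual scatter and compound 3 well beyond it. Compound 1 `CC#CC(CC(=O)O)c1ccc(OCC2COc3ccc(Cl)cc3O2)cc1` gives 100 nM; a 2.0-fold lower number from compound 1 to compound 2 (0.30 log units; within the scatter), and the fact that one of compounds 1 and 2 is drawn with a defined configuration and the other without, at the place where they differ is the only difference between the two. Compound 3 `CC#C[C@@H](CC(=O)O)c1ccc(OC[C@H]2COc3ccc(C#N)cc3O2)cc1` gives 2100 nM in this assay, so that a 42-fold higher number from compound 2 to compound 3 (1.62 log units; beyond the scatter). Compound 4 `CC#C[C@@H](CC(=O)O)c1ccc(OC[C@H]2COc3cc(Cl)c(Cl)cc3O2)cc1` differs from compound 2 by chloro in place of hydrogen on an aromatic carbon. Going by the values given here, no measured step adds a second chloro group; the step from compound 2 to compound 3 exchanges the existing chloro group and does not cover this change. The step is therefore expected to stay within the scatter, a 1.2-fold higher number from compound 2 to compound 4 (0.08 log units; within the scatter). For compound 4 the estimate in this assay is 60 nM, with a range from 15 nM to 250 nM.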

Compound 4, half-maximal effective concentration: 150 nM
Beside the measured number, compound 4's estimate is 2.5-fold (0.40 log units) below it; the measured number falls inside the stated range.
By their numbers in this assay, from the lowest: compounds 2, 1 and 4 (each within the scatter of the next, the first and the last beyond it); then compound 3.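

Chloro in place of hydrogen on this aromatic carbon, ortho to a chloro group, gives a 3.0-fold higher number from compound 2 to compound 4 (0.48 log units; beyond the scatter) in this assay. Going by these compounds alone, the earlier compounds varied only the existing chloro group, where nitrile gave a 42-fold higher number from compound 2 to compound 3 (1.62 log units; beyond the scatter); this step is the first reading at a ring hydrogen, and the change is modest by comparison. Nothing at hand explains this step.

The compounds shown leave open whether fluoro, methyl or methoxy on this carbon would read like chloro. Also open, on these data alone, is whether chloro on the other ring hydrogens would give a similar step.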